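Adding a Second Chloro Group to a Serotonin Receptor Binder

This account rests on a few compounds, and the source may have more. Where it says the series, first, only, none or still open, it means among the compounds named here.

Compound 1 `CN1CCC(n2cc(S(=O)(=O)c3cccc(Cl)c3)c3cccnc32)C1` gives 1.5 nM in an assay on HeLa cells for displacement of a labelled ligand from 5-hydroxytryptamine receptor 6 (Homo sapiens); on this read-out higher numbers stand for weaker inhibition and lower numbers for stronger inhibition. Compound 2 `O=S(=O)(c1cccc(Cl)c1)c1cn(C2CCCNC2)c2ncccc12` gives 1.3 nM in this assay, and the two numbers lie within the scatter of each other, as a 1.2-fold lower number from compound 1 to compound 2 (0.06 log units; within the scatter) shows. Compound 3 `O=S(=O)(c1cc(Cl)cc(Cl)c1)c1cn(C2CCCNC2)c2ncccc12` has not yet been measured; it differs from compound 2 by chloro in place of hydrogen on an aromatic carbon. Among the compounds with values here, no measured step touches the 3-chlorophenyl part of the molecule, since the only step at hand concerns a different part, so nothing here points to a change beyond the scatter. Compound 3 is therefore expected to give 1.3 nM, within 0.5 nM to 4 nM, an expected no change at the digits printed from compound 2 to compound 3 (within the scatter).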

Compound 3, inhibition constant: 6.1 nM
Compound 3: middle estimate off by 4.7-fold (0.67 log units), on the low side; the measured number lies above the stated range.
By their numbers in this assay, from the lowest: compounds 2 and 1 (each within the scatter of the next); then compound 3.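

The 3-chlorophenyl part is not indifferent to change: in this assay a second chloro group, meta to the first, brings a 4.7-fold higher number from compound 2 to compound 3 (0.67 log units; beyond the scatter) and this modest step lies beyond the scatter, unlike the earlier step on the aromatic nitrogen. Adding chloro at this place therefore costs some binding strength. Nothing measured here accounts for that loss.

Going by these compounds, whether fluoro or methoxy at this place would cost as much remains open. So does whether the cost of the new chloro group depends on the first one being present.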